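The compounds below may be only part of what the source reports. "The series", "measured", "known", "first", "only" and "open" are said of these compounds alone.

Of the compounds shown here, three built on one shared core have been measured in a functional assay on Right cardiac atrium for agonist activity at histamine H2 receptor (Cavia porcellus), with a stated time of 30 min, in the presence of a further agent that is not named here; a lower number here means that less compound is needed, a higher number that more compound is needed for the effect. Compound 1, `Cc1nc(N)sc1CCCN/C(N)=N/C(=O)NC(C)c1ccc(Br)cc1`, gives 55 nM. Compound 2, `Cc1nc(N)sc1CCCN/C(N)=N/C(=O)NC(c1ccccc1)C(C)C`, gives 34.7 nM, and compound 3, `Cc1nc(N)sc1CCCN/C(N)=N/C(=S)N[C@H](C)c1ccccc1`, gives 89.1 nM. Among these three numbers compound 1 holds the second highest place, yet its gap to compound 2 and its gap to compound 3 both lie within the usual spread of repeated measurements, so the three values are best read as alike rather than as a ranking.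

Compound 4, `Cc1ccc(C(C)NC(=O)/N=C(\N)NCCCc2sc(N)nc2C)cc1`, has not yet been measured in this assay. It differs from compound 1 in one place: methyl in place of bromo on an aromatic carbon. No ring is added or lost, and nothing changes in charge, hydrogen-bond donors or acceptors. Among the measured compounds shown here, no measured pair on this core shows this particular swap, so the expectation can rest only on the closeness of the three values seen so far, which suggest that the outer part of the molecule tolerates variation without large shifts. The step of no change at the digits printed from compound 1 to compound 4 (within the scatter) is therefore expected to be small, in no fixed direction, and not beyond the scatter. Compound 4 is estimated at 55 nM, with a range from 25 nM to 120 nM.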

Compound 4, half-maximal effective concentration: 22.4 nM
Compound 4: the middle estimate sits 2.5-fold (0.39 log units) above what was measured, outside the stated range (below it).
By their numbers in this assay, from the lowest: compounds 4, 2, 1 and 3 (each within the scatter of the next, the first and the last beyond it).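

In this assay the exchange of 4-bromophenyl for 4-methylphenyl gives a 2.5-fold lower number from compound 1 to compound 4 (0.39 log units; beyond the scatter) and so provides the first listed step on this core that stands beyond the scatter, although it is only a modest one. The earlier values lay too close together to show that any single place mattered, whereas this pair shows that the group on an aromatic carbon, para to a large group, can shift the number even when one heavy atom simply replaces another and the counts of rings, charges, hydrogen-bond donors and hydrogen-bond acceptors stay the same. Nothing in the available data explains why the number moves with this exchange.

A single pair cannot show whether other groups at this place, such as fluoro, methoxy or a longer chain like ethyl or propyl, would lower the number further, leave it unchanged or raise it. It also leaves open whether the same exchange of bromo for methyl would produce a step of similar size on a compound that differs elsewhere, such as one carrying the thiocarbonyl of compound 3.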